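The source may report more compounds than this note shows. Statements on the series, on what has been measured and on what is new or still open speak of the compounds shown alone.

Three measured compounds share one core and differ only in the group carried on the six-membered aromatic ring. Compound 1 `Nc1scc(-c2ccc(Cl)cc2)c1C(=O)c1ccccc1` gives 46% in a functional assay on CHO cells for agonist activity at adenosine receptor A1 (Homo sapiens), read by fluorescence and ERK phosphorylation, with stated times of 30 min and 1.5 h, tested at 3 uM; a lower number here means a weaker effect, a higher number a stronger effect of the compound at the concentration tested. Compound 2 `Nc1scc(-c2ccc(I)cc2)c1C(=O)c1ccccc1` gives 51% in this assay, and compound 3 `Nc1scc(-c2ccc([N+](=O)[O-])cc2)c1C(=O)c1ccccc1` gives 50%. Among these three numbers compound 3 stands second highest, but the step of a number 1 percentage points lower from compound 2 to compound 3 (within the scatter) and the step of a number 4 percentage points higher from compound 1 to compound 3 (within the scatter) both lie within the scatter, as does the step of a number 5 percentage points higher from compound 1 to compound 2 (within the scatter), so none of the three can be ranked against the others.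

Compound 4 `COc1ccc(-c2csc(N)c2C(=O)c2ccccc2)cc1` has not yet been measured. It differs from compound 3 in one place: methoxy in place of nitro on an aromatic carbon. Within the data shown here, no measured step puts methoxy in place of another group, so nothing bears directly on this change. The steps that do exist, each exchanging one group for another at the same place, were all small. The step of a number 2 percentage points lower from compound 3 to compound 4 (within the scatter) that the estimate means is therefore expected to stay within the scatter, with no clear direction. The estimate for compound 4 in this assay is 48%, with a range from 30% to 65%.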

Compound 4, a percentage reported as activity, at one concentration (the size of the read-out at that concentration, not a potency): 52%
Beside the measured number, compound 4's estimate is 4 percentage points below it; measured number inside the range.
By their numbers in this assay, from the lowest: compounds 1, 3, 2 and 4 (each within the scatter of the next).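

With methoxy on the aromatic carbon para to a large group, the read-out in this assay stays level with that of the three other groups: the steps are a number 2 percentage points higher from compound 3 to compound 4 (within the scatter), a number 1 percentage points higher from compound 2 to compound 4 (within the scatter) and a number 6 percentage points higher from compound 1 to compound 4 (within the scatter). The exchange of nitro for methoxy removes the double bond outside aromatic rings and leaves fewer heavy atoms and fewer hydrogen-bond acceptors at this place, yet this larger change in the counted features brings no step beyond the scatter. Across the four compounds, then, chloro, iodo, nitro and methoxy cannot be told apart at this position, and no compound among them goes against that reading.

Nothing available explains why the read-out stays level across these groups. From the compounds shown here alone, it remains open whether an amine, a carboxylic acid or a longer chain at this place would separate from these four, and, since each number comes from a single concentration, whether compounds that look alike here would also show a like effect at other concentrations.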